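Replacing the Diethylcarbamoyl Group of Compound 2

This account rests on a few compounds, and the source may have more. Where it says the series, first, only, none or still open, it means among the compounds named here.

In a functional assay with Oryctolagus cuniculus as the target (a higher number here means a weaker inhibitor, a lower number a stronger inhibitor), compound 1 (`COc1ccc(-c2nc(/N=C(\N)NC3CCCCC3)sc2-c2ccc(OC)cc2)cc1`) gives > 1000 nM, which is a limit of the assay. Compound 2 (`CCN(CC)C(=O)c1nc(-c2ccc(OC)cc2)c(-c2ccc(OC)cc2)s1`) gives < 10 nM, also a limit and the lower of the two values. Compound 3 (`CCOC(=O)/C(C#N)=C/c1nc(-c2ccc(OC)cc2)c(-c2ccc(OC)cc2)s1`) carries 2-cyano-2-(ethoxycarbonyl)ethenyl in place of diethylcarbamoyl on an aromatic carbon. Among the measured compounds shown here, the only measured step, an at least 100-fold lower number from compound 1 to compound 2 (2.00 log units; beyond the scatter), also changes the group on an aromatic carbon and shows that such a change can be large, though not how large this one will be. A moderate rise toward weaker inhibition is expected, an at least 2.5-fold higher number from compound 2 to compound 3 (0.39 log units; beyond the scatter). For compound 3 the estimated value is 25 nM, with an expected range of 3 nM to 300 nM.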

Compound 3, half-maximal inhibitory concentration: < 10 nM
Compound 3 gave a limit, no number; the forecaster's own chance of this, stated with the estimate: 35%; middle value at least 2.5-fold (0.39 log units) away from the limit.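

With 2-cyano-2-(ethoxycarbonyl)ethenyl on this aromatic carbon, compound 3 gives < 10 nM, which is a limit of this assay and not a number. The change from compound 1 gives an at least 100-fold lower number from compound 1 to compound 3 (2.00 log units; beyond the scatter), so a large step at this position is not tied to diethylcarbamoyl. The step from compound 2 to compound 3 cannot be read, and any difference between them stays hidden: the limit of < 10 nM in this assay, at which 2 of the 3 values shown sit.

Going by these compounds, how far the numbers of compound 2 and compound 3 lie beyond that limit remains open. So does whether an amine or a carboxylic acid on this carbon would reach the same limit.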